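This account rests on a few compounds, and the source may have more. Where it says the series, first, only, none or still open, it means among the compounds named here.

Measured so far in an assay on Prostate gland for inhibition of steroid 5-alpha-reductase (Rattus norvegicus); on this read-out lower numbers stand for stronger inhibition and higher numbers for weaker inhibition:
compound 1 `CCCCCn1ccc2cc(/C(C)=C/C(=O)Nc3ccccc3OCCCC(=O)O)ccc21` — compound 1 gives 23 nM;
compound 2 `CC(C)=CCn1ccc2cc(/C(C)=C/C(=O)Nc3ccccc3OCCCC(=O)O)ccc21` — compound 2 gives 120 nM;
compound 3 `C/C(=C\C(=O)Nc1ccccc1OCCCC(=O)O)c1ccc2c(ccn2Cc2ccccc2C)c1` — compound 3 gives 69 nM.

Compound 2 holds the highest of the three numbers: the step of a 5.2-fold higher number from compound 1 to compound 2 (0.72 log units; beyond the scatter) lies beyond the scatter, while the step of a 1.7-fold lower number from compound 2 to compound 3 (0.24 log units; within the scatter) does not. Compound 4 `C/C(=C\C(=O)Nc1ccccc1OCCCC(=O)O)c1ccc2c(ccn2Cc2ccc(F)cc2)c1` has not yet been measured; its difference from compound 2 is 4-fluorophenyl in place of 2-methylprop-1-en-1-yl on a saturated chain carbon bound to an aromatic nitrogen. Within the data shown here, the one measured step that bears directly on this is a 1.7-fold lower number from compound 2 to compound 3 (0.24 log units; within the scatter), where an aromatic ring also entered at the same place and the number moved only within the scatter. Among the measured compounds shown here, no other pair informs the change. The step of a 1.7-fold lower number from compound 2 to compound 4 (0.23 log units; within the scatter) is therefore expected to be small, if anything a slightly lower number. Compound 4 is estimated at 70 nM, with a range of 30 nM to 170 nM.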

Compound 4, half-maximal inhibitory concentration: 97 nM
For compound 4 the middle estimate is 1.4-fold (0.14 log units) below the measured one, within the range that was stated.
By their numbers in this assay, from the lowest: compound 1; then compounds 3, 4 and 2 (each within the scatter of the next).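

In this assay the 4-fluorophenyl group on the saturated chain carbon bound to an aromatic nitrogen cannot be told apart from the two other non-butyl groups: a 1.2-fold lower number from compound 2 to compound 4 (0.09 log units; within the scatter) and a 1.4-fold higher number from compound 3 to compound 4 (0.15 log units; within the scatter) both stay within the scatter. Butyl alone stands apart, with a 4.2-fold higher number from compound 1 to compound 4 (0.63 log units; beyond the scatter) beyond the scatter, and this now holds against three different replacements. No supporting measurement accounts for this separation. Still open, going by these compounds, is whether a longer chain such as hexyl would go further than butyl. On these data alone, an amine or a carboxylic acid at the end of that chain also remains untested in these data.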